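Alkyl in place of aryl on the chain carbon: compound 4

The compounds below may be only part of what the source reports. "The series", "measured", "known", "first", "only" and "open" are said of these compounds alone.

Compound 3 `COc1ccc(Cn2c(=O)n(C3OC(CO)[C@@H](O)[C@H]3O)c3nc(N)nc(O)c32)cc1` gives 14% in a functional assay on the whole organism with Mus musculus as the target; a higher number here means a larger maximal response, a lower number a smaller maximal response. Going by the values given here, of the three numbers known it stands second highest; compound 1 `Nc1nc(O)c2c(n1)n(C1OC(CO)[C@@H](O)[C@H]1O)c(=O)n2C/C=C/c1ccccc1` gives 5%, within the scatter of compound 3, while compound 2 `C=CCn1c(=O)n([C@@H]2O[C@H](CO)[C@H]3OC(CCC)(CCC)O[C@H]32)c2nc(N)nc(O)c21` gives 38%, beyond the scatter and higher. Compound 4 `CCCCCCCCCCn1c(=O)n(C2OC(CO)[C@@H](O)[C@H]2O)c2nc(N)nc(O)c21` is not yet measured. It differs from compound 3 in one place: nonyl in place of 4-methoxyphenyl on a saturated chain carbon bound to an aromatic nitrogen. Among the compounds with values here, the only measured step at that place, a number 9 percentage points higher from compound 1 to compound 3 (within the scatter), lies within the scatter, so an exchange of the group on a saturated chain carbon bound to an aromatic nitrogen has so far not moved the maximal response. Compound 2 differs from compound 3 in more than one place, so its value does not isolate that exchange. Within the data shown here, a move from an aromatic group to nonyl has no close precedent in this set, which widens the range. The step of a number 4 percentage points higher from compound 3 to compound 4 (within the scatter) is expected to stay within the scatter. Compound 4 is estimated at 18%, with a range from 5% to 40%.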

Compound 4, largest response reached (reported as maximal response), in percent of the reference or control that the assay uses: 0%
The estimate for compound 4 lay 18 percentage points above the measured number; measured number outside the range, below it.
By their numbers in this assay, from the lowest: compounds 4, 1 and 3 (each within the scatter of the next, the first and the last beyond it); then compound 2.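

Nonyl in place of 4-methoxyphenyl on a saturated chain carbon bound to an aromatic nitrogen gives in this assay the first step at this place that passes the scatter (a number 14 percentage points lower from compound 3 to compound 4 (beyond the scatter)). The exchange of 2-phenylethenyl for nonyl at the same place stays within the scatter (a number 5 percentage points lower from compound 1 to compound 4 (within the scatter)), so the group here can matter, but the two comparisons with nonyl do not separate into one clear trend. No measured evidence bears on the reason for this result.

From the compounds shown here alone, whether a shorter chain such as propyl, or a decyl chain ending in an amine or a carboxylic acid, would change the maximal response remains open. Compound 2 at 38% differs from the others in more than one place, so its steps cannot be read.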